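Swapping methoxy for methyl on the shared core

This account rests on a few compounds, and the source may have more. Where it says the series, first, only, none or still open, it means among the compounds named here.

Of the compounds shown here, two carrying the shared core have been measured in a functional assay on the whole organism (Cricetulus griseus) with Cricetinae gen. sp. as the target; a higher number here means that more compound is needed for the effect, a lower number that less compound is needed. Compound 1, `Cc1ccccc1-c1n[nH]c(-c2ccccc2)n1`, gives 0.3 mg/kg; 0.3 mg/kg (2 entries) in this assay across two entries. Among the measured compounds shown here, compound 2, `COc1ccccc1-c1n[nH]c(-c2ccccc2C)n1`, gives 0.5 mg/kg in this assay, the only number it has there; a further entry for compound 2 yielded no single number. The two values lie within the usual scatter of each other, so no order between compound 1 and compound 2 can be read from them.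

Compound 3, `Cc1ccccc1-c1n[nH]c(-c2ccccc2C)n1`, has not yet been measured. It differs from compound 2 by methyl in place of methoxy on an aromatic carbon. For the measured compounds named here, no comparable step between measured compounds exists in this set, so the expectation rests on how close compound 1 and compound 2 already sit. The step from compound 2 to compound 3 in this assay is expected to be small, a 1.3-fold lower number from compound 2 to compound 3 (0.10 log units; within the scatter), not beyond the scatter in either direction. Compound 3 is therefore estimated to give 0.4 mg/kg in this assay, with a range from 0.15 mg/kg to 1 mg/kg.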

Compound 3, dose for half-maximal effect: 0.7 mg/kg
Compound 3: middle estimate off by 1.8-fold (0.24 log units), on the low side; the measured number falls inside the stated range.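

In this assay, among the compounds shown here, the swap of methyl in place of methoxy on an aromatic carbon, ortho to a large group, gives the only single-place comparison in this set: a 1.4-fold higher number from compound 2 to compound 3 (0.15 log units; within the scatter) and so stays within the scatter. At this position, then, the read-out does not separate the two groups, even though the methoxy brings one hydrogen-bond acceptor and the methyl none. Nothing at hand accounts for this result.

From the compounds shown here alone, whether the same place would accept a group other than these two, such as an amine, a carboxylic acid or a longer chain, remains open. Going by these compounds, it is also open whether the swap would read the same way on another compound, since this single step is the only one available.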